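Indanyl Urea on the Shared Core: An Expected Value

A few compounds are considered here, and "the series" means these few. Any claim that something is new, unique, unknown or untested is made for them only; others in the source may bear on it.

Compound 3 `COC(=O)c1cc(=O)c2cc(NC(=O)Nc3cccc(C(C)=O)c3)ccc2[nH]1` is known in a functional assay on SEM cells (Homo sapiens) for antiproliferative activity, with a stated time of 72 h (a higher number here means that more compound is needed for the effect, a lower number that less compound is needed), only by a limit, > 8080 nM. Compound 2 `COC(=O)c1cc(=O)c2cc(NC(=O)Nc3ccc(Cl)c(Cl)c3)ccc2[nH]1` likewise shows only a limit in this assay, > 6350 nM. Compound 1 `COc1ccc(-c2c(Cl)c(=O)c3c(OC)cc(OC)cc3n2S(=O)(=O)c2ccc(OC)cc2)cc1` has "not determined" (no result reported) in this assay. Among the compounds with values here, the one measured step, a step that the two limits leave unreadable from compound 2 to compound 3, stays unreadable, as the two entries the limit of > 6350 nM in this assay, at which 1 of the 3 values shown sits, and the limit of > 8080 nM in this assay, at which 1 of the 3 values shown sits, are both limits. Compound 4 `COC(=O)c1cc(=O)c2cc(NC(=O)Nc3ccc4c(c3)CCC4)ccc2[nH]1` differs from compound 3 by 2,3-dihydro-1H-inden-5-yl in place of 3-acetylphenyl on an amide-type nitrogen. No readable measured step bears on this exchange, so neither direction nor size can be drawn from the numbers. The step from compound 3 to compound 4 is therefore expected to be a step that the limit leaves unreadable from compound 3 to compound 4, with no direction supported. Compound 4 is expected to give about 10000 nM, within 3000 nM to 30000 nM, quite possibly again only as a limit.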

Compound 4, half-maximal effective concentration: > 24100 nM
Compound 4: no number, only a limit; the forecaster's own chance of this, stated with the estimate: 70%; middle value at least 2.4-fold (0.38 log units) away from the limit.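

Within the data shown here, compound 2, compound 3 and compound 4 each stand only as a limit in this assay, so no step among them can be read. The compounds shown leave open whether exchanging the group on the amide-type nitrogen changes the effect at all.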